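Propyl for neopentyloxy on the aryl ring of compound 2

This account rests on a few compounds, and the source may have more. Where it says the series, first, only, none or still open, it means among the compounds named here.

Measured compounds:
compound 1 `CN(C)C(=O)c1cccnc1NCCCN1CCN(c2ccccc2OCC(F)(F)F)CC1`: 15.9 nM
compound 2 `CN(C)C(=O)c1cccnc1NCCCN1CCN(c2ccccc2OCC(C)(C)C)CC1`: 50.1 nM

Two compounds share one core and differ only in the group on the oxygen of the aromatic ring. In a functional assay on aorta for antagonist activity at Alpha-1D adrenergic receptor (Rattus norvegicus) (on this read-out higher numbers stand for weaker binding and lower numbers for tighter binding), compound 1 gives 15.9 nM, and compound 2 gives 50.1 nM. Among the measured compounds shown here, the one measured step is a 3.2-fold higher number from compound 1 to compound 2 (0.50 log units; beyond the scatter), so compound 2 stands with the higher of the two numbers, and its distance from compound 1 lies beyond the scatter.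

Compound 3 `CCCc1ccccc1N1CCN(CCCNc2ncccc2C(=O)N(C)C)CC1` has not been measured in this assay. The change from compound 2 is propyl in place of neopentyloxy on an aromatic carbon. For the measured compounds named here, no measured step covers this change: the only step in hand exchanges one group for another on the chain carbon bound to the oxygen, whereas here the oxygen itself leaves along with the branched chain and a shorter chain enters on the aromatic carbon. That step showed a modest weakening when a larger group came in, which gives little guidance when the group becomes smaller and the oxygen is lost.

For compound 3 the step is expected to be a 1.7-fold lower number from compound 2 to compound 3 (0.22 log units; within the scatter), with wide uncertainty. Compound 3 is therefore estimated at 30 nM, within a range from 8 nM to 120 nM.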

Compound 3, dissociation constant: 31.6 nM
Estimate against measurement, compound 3: 1.1-fold (0.02 log units) below; the range from low to high includes it.
By their numbers in this assay, from the lowest: compounds 1, 3 and 2 (each within the scatter of the next, the first and the last beyond it).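

In this assay, among the compounds shown here, the earlier compounds varied only the far end of a chain held on the ring through oxygen, so they could not show whether that oxygen was needed at this aromatic carbon, ortho to a large group. Compound 3 carries propyl with no oxygen there, and the exchange gives a 1.6-fold lower number from compound 2 to compound 3 (0.20 log units; within the scatter) against neopentyloxy and a 2.0-fold higher number from compound 1 to compound 3 (0.30 log units; within the scatter) against 2,2,2-trifluoroethoxy, so on these three compounds an all-carbon chain reads within the scatter of both oxygen-linked groups, even though those two groups lie beyond the scatter of each other. No independent evidence bears on this result, so the data give no explanation for it.

The step from compound 2 to compound 3 removes the oxygen and shortens the chain at once, so the two changes remain unseparated, and a neopentyl group on the same aromatic carbon would tell them apart. From the compounds shown here alone, how a butyl chain, a methoxy group or an amine would read at this position also stays open, as does whether propyl would keep its place on a core other than the shared one.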